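The source may hold more compounds than are shown below. What is called first, only, known or untested is meant among the compounds shown, and "the series" means these compounds.

- Compound 1 `COc1cc(OC)c(/C=C/S(=O)(=O)Cc2ccc(OC)c(N[C@@H](C)C(=O)O)c2)c(OC)c1`: 25 nM
- Compound 2 `COc1cc(OC)c(/C=C/S(=O)(=O)Cc2ccc(OC)c(NC(C(=O)O)c3ccccc3)c2)c(OC)c1`: 20 nM

In a functional assay on DU-145 cells (Homo sapiens) for cytotoxicity, read by trypan blue exclusion, with a stated time of 96 h (on this read-out lower numbers stand for stronger inhibition and higher numbers for weaker inhibition), compound 2 gives 20 nM and compound 1 gives 25 nM, so the two stand within the scatter of each other. Compound 3 `COc1cc(OC)c(/C=C/S(=O)(=O)Cc2ccc(OC)c(NC(C(=O)O)c3ccc(Br)cc3)c2)c(OC)c1` keeps everything in compound 2 except for one substitution on the phenyl ring of the carboxy(phenyl)methyl group: bromo in place of hydrogen on an aromatic carbon. In words, this is phenyl to 4-bromophenyl, with the bromo para to a large group.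

Among the compounds with values here, only one measured step bears on this change. It is a 1.3-fold lower number from compound 1 to compound 2 (0.10 log units; within the scatter), which concerns the same group on the nitrogen but does not involve a bromo. Within the data shown here, no measured compound carries a bromo, so the data give no direct reading of this substitution. That single step, small as it is, gives no reason to expect a shift in either direction. The expected step is no change at the digits printed from compound 2 to compound 3 (within the scatter), an estimate of no change beyond the scatter. For compound 3 the estimated value is 20 nM, with an expected range of 8 nM to 50 nM.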

Compound 3, half-maximal inhibitory concentration: 300 nM
Compound 3: middle estimate off by 15-fold (1.18 log units), on the low side, and the stated range ends below it.
By their numbers in this assay, from the lowest: compounds 2 and 1 (each within the scatter of the next); then compound 3.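

In this assay, the phenyl ring of the carboxy(phenyl)methyl group proves sensitive to substitution: bromo in place of hydrogen, para to a large group, gives a 15-fold higher number from compound 2 to compound 3 (1.18 log units; beyond the scatter) and so a large step from a single heavy atom, whereas replacing 1-carboxyethyl with carboxy(phenyl)methyl had stayed within the scatter. Against the smaller group on the nitrogen, the (4-bromophenyl)(carboxy)methyl group also stands apart, with a 12-fold higher number from compound 1 to compound 3 (1.08 log units; beyond the scatter) as a second large step, while compound 2, with its unsubstituted phenyl ring, lies within the scatter of compound 1, so an aromatic ring on this carbon is not enough by itself to bring the loss. Nothing among the available data explains why this one bromo costs so much.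

From the compounds shown here alone, whether the loss is particular to bromo or would follow any group at this place remains open, as a fluoro, a methoxy or a hydroxy on the same ring carbon could read quite differently. Also open, going by these compounds, is whether an ester or an amide in place of the carboxylic acid would change the standing of the 4-bromophenyl compound.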